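The source may report more compounds than this note shows. Statements on the series, on what has been measured and on what is new or still open speak of the compounds shown alone.

Working notes on the series. The shared core appears in compound 1 `Cc1cc(-c2cccc(F)c2)c2ncc(CSCCc3ccccc3)n2c1`, which in an ADME assay on HEL cells (Homo sapiens) for cytotoxicity, with a stated time of 3 days (on this read-out lower numbers stand for higher toxicity in this test and higher numbers for lower toxicity in this test), gives 35 ug/mL. Compound 2 `Cc1cc(-c2cccs2)cn2c(CSCCc3ccccc3)cnc12` gives 32 ug/mL in this assay. For compound 3 `Cc1cc(-c2cccc(C#N)c2)cn2c(CSCCc3ccccc3)cnc12` only a limit of the assay is known, > 50 ug/mL in this assay. One of the three values shown sits at that limit (the limit of > 50 ug/mL in this assay, at which 1 of the 3 values shown sits).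

Compound 4 `Cc1cc(-c2ccc(O)cc2)cn2c(CSCCc3ccccc3)cnc12` is still to be measured; compared with compound 3 it carries 4-hydroxyphenyl in place of 3-cyanophenyl on an aromatic carbon. For the measured compounds named here, the only measured step on this aromatic carbon, an at least 1.5-fold higher number from compound 2 to compound 3 (0.19 log units; that floor lies within the scatter), changes the aryl group and stays within the scatter at its floor; no measured step covers a 4-hydroxyphenyl. Compound 3 stands at the limit, so no step beyond the scatter is expected from it; the expected step is an at least 1.1-fold lower number from compound 3 to compound 4 (0.04 log units; that floor lies within the scatter). Compound 4 is thus expected near 45 ug/mL, between 25 ug/mL and 80 ug/mL in this assay, with a fair chance of again only a limit.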

Compound 4, half-maximal cytotoxic concentration: > 50 ug/mL
Compound 4 gave a limit, no number (the forecaster's own chance of this, stated with the estimate: 50%); middle value at least 1.1-fold (0.04 log units) from the limit.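

Compound 4 joins compound 3 at the limit of the assay, so two different aryl groups on this aromatic carbon, 3-cyanophenyl and 4-hydroxyphenyl, now give no number in this assay. Starting from thiophen-2-yl, the change to 4-hydroxyphenyl gives an at least 1.5-fold higher number from compound 2 to compound 4 (0.19 log units; that floor lies within the scatter), which stays within the scatter at its floor. The step between compound 3 and compound 4 cannot be read, as both stand at the same limit: the limit of > 50 ug/mL in this assay, at which 2 of the 4 values shown sit.

As far as these compounds go, how far these two aryl groups lie from each other stays open. Also open, from the compounds shown here alone, is what an amine or a carboxylic acid on this aromatic carbon would give.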